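The compounds below may be only part of what the source reports. "The series", "measured", "known", "first", "only" and "open" are said of these compounds alone.

Measured compounds:
Compound 1 `S=C(N/N=C/c1ccc2ccccc2n1)Nc1cccc(Cl)c1` — 48100 nM
Compound 2 `N#Cc1ccc(NC(=S)N/N=C/c2ccc3ccccc3n2)cc1` — 15600 nM
Compound 3 `Cc1ccccc1NC(=S)N/N=C/c1ccc2ccccc2n1` — 42300 nM

In a functional assay on HT-29 cells (Homo sapiens) for antiproliferative activity, read by sulforhodamine B assay, with a stated time of 72 h (on this read-out lower numbers stand for stronger inhibition and higher numbers for weaker inhibition), compound 3 stands second highest of the three numbers. Its nearest neighbour is compound 1, with a 1.1-fold lower number from compound 1 to compound 3 (0.06 log units; within the scatter) reading as a change within the scatter; its furthest is compound 2, with a 2.7-fold higher number from compound 2 to compound 3 (0.43 log units; beyond the scatter).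

Compound 4 `FC(F)(F)c1ccccc1NC(=S)N/N=C/c1ccc2ccccc2n1` differs from compound 3 in one place: trifluoromethyl in place of methyl on an aromatic carbon. The change sits on an aromatic carbon of a six-membered aromatic ring of carbon only, ortho to a large group.

Within the data shown here, none of the measured steps concerns this place or this pair of groups. Among the measured compounds shown here, the step of a 3.1-fold lower number from compound 1 to compound 2 (0.49 log units; beyond the scatter) and the step of a 2.7-fold higher number from compound 2 to compound 3 (0.43 log units; beyond the scatter) both exchange one whole aryl group on the amide-type nitrogen for another, so they tell only that such exchanges have stayed modest. For the measured compounds named here, the data offer no step in which methyl gives way to trifluoromethyl.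

Compound 4 is therefore expected to stay close to compound 3, with an estimated step of a 1.1-fold lower number from compound 3 to compound 4 (0.05 log units; within the scatter) that lies within the scatter. The estimate for compound 4 in this assay is 38000 nM, in a range from 13000 nM to 110000 nM.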

Compound 4, half-maximal inhibitory concentration: 18100 nM
The estimate for compound 4 lay 2.1-fold (0.32 log units) above the measured number; the range from low to high includes it.
By their numbers in this assay, from the lowest: compounds 2 and 4 (each within the scatter of the next); then compounds 3 and 1 (each within the scatter of the next).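

In this assay, this place on the aromatic ring responds to substitution: with the rest of compound 3 unchanged, trifluoromethyl in place of methyl gives a 2.3-fold lower number from compound 3 to compound 4 (0.37 log units; beyond the scatter), a modest step beyond the scatter towards stronger inhibition. The earlier steps shown here exchanged whole aryl groups, whereas this one shows that changing a single group on the ring, ortho to a large group, is enough to shift the number. No measurement at hand accounts for this step.

Whether the step is particular to trifluoromethyl remains open, as the compounds shown carry only methyl and trifluoromethyl here, and neither a chlorine atom, a methoxy group nor an amine appears at this place. Also open, as far as these compounds go, is whether trifluoromethyl would give a similar step on another aromatic carbon of the ring.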